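Adding a Nitro Group to Two Related Amides

A few compounds are considered here, and "the series" means these few. Any claim that something is new, unique, unknown or untested is made for them only; others in the source may bear on it.

Compound 1 `CCS(=O)(=O)Nc1ccc(NC(=O)c2ccc(Cl)cc2)cc1Cl` and compound 3 `O=C(Nc1ccc(NS(=O)(=O)C(F)(F)F)c(F)c1)c1ccc(Cl)cc1` are built on two different cores; the difference between the two cores is not broken down here. Both were tested in an ADME assay on HEK293 cells (Homo sapiens) for cytotoxicity, read by MTT assay, with a stated time of 48 h; on this read-out higher numbers stand for weaker inhibition and lower numbers for stronger inhibition. Compound 1 gives only a limit, > 250000 nM, and not a number. Compound 3 gives 79000 nM in this assay. Compound 2 `CCS(=O)(=O)Nc1ccc(NC(=O)c2ccc(Cl)c([N+](=O)[O-])c2)cc1Cl` arises from compound 1 by nitro in place of hydrogen on an aromatic carbon, and in this assay compound 2 gives 63800 nM. That change brought an at least 3.9-fold lower number from compound 1 to compound 2 (0.59 log units; beyond the scatter); the step is known only as a bound because compound 1 sits at the limit of > 250000 nM in this assay, at which 1 of the 3 values shown sits. The values of compound 2 and compound 3 lie within the usual scatter of each other, so no order between them can be read.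

Compound 4 `O=C(Nc1ccc(NS(=O)(=O)C(F)(F)F)c(F)c1)c1ccc(Cl)c([N+](=O)[O-])c1` is related to compound 3 by nitro in place of hydrogen on an aromatic carbon, the same change in the same surroundings as in the first pair, now made on the core of compound 3. Compound 4 has not yet been measured in this assay. The expected step is a 3.2-fold lower number from compound 3 to compound 4 (0.50 log units; beyond the scatter), resting on the change having given an at least 3.9-fold lower number from compound 1 to compound 2 (0.59 log units; beyond the scatter) in the first pair, while the bound nature of that earlier step leaves its true size open. On that basis compound 4 is estimated at 25000 nM, with a range expected from 8000 nM to 80000 nM.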

Compound 4, half-maximal inhibitory concentration: 194000 nM
Beside the measured number, compound 4's estimate is 7.8-fold (0.89 log units) below it; the measured number lies above the stated range.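

In this assay, the nitro group on the core of compound 3 brought a 2.5-fold higher number from compound 3 to compound 4 (0.39 log units; beyond the scatter), so the same change moved the number in opposite directions on the two cores: the same change on two cores in this assay, an at least 3.9-fold lower number (0.59 log units; beyond the scatter) from compound 1 to compound 2 and a 2.5-fold higher number (0.39 log units; beyond the scatter) from compound 3 to compound 4, at least 9.6-fold (0.98 log units) apart, beyond the scatter of two such steps

This shows that, for these two pairs, the result of adding the nitro group on one core could not be carried over to the other, not even in its direction. It does not show why the two steps part ways or how the change would behave on any further core, and the size of the first step stays open, as compound 1 gives only a limit: the limit of > 250000 nM in this assay, at which 1 of the 4 values shown sits.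

The two cores differ in more than one place, and the compounds shown do not separate those differences, so it remains open which part of the core decides the direction of the step. As far as these compounds go, it also remains open whether a different group on the same aromatic carbon, such as an amine or a carboxylic acid, would move the number in opposite directions on these two cores as the nitro group does.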